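The compounds below may be only part of what the source reports. "The series", "measured", "known", "first", "only" and "open" are said of these compounds alone.

Working notes on the naphthol series, read in an assay on RBL-1 cells with Polyunsaturated fatty acid 5-lipoxygenase (Rattus norvegicus) as the target; a higher number here means a weaker inhibitor, a lower number a stronger inhibitor.

Of the compounds shown here, three have numbers so far. Compound 1 `Oc1c(Cc2ccccn2)ccc2ccccc12` gives 390 nM in this assay. Among the measured compounds shown here, compound 3 `Oc1c(Cc2ccncc2)ccc2ccccc12` gives 140 nM; the single one-point step on record, a 2.8-fold lower number from compound 1 to compound 3 (0.44 log units; beyond the scatter), is the only measured move in the set that goes beyond the scatter. Compound 2 `COc1ccc(Cc2ccc3ccccc3c2O)cc1` gives 75 nM, the lowest of the three numbers; against compound 3 it sits within the scatter, and only against compound 1 does the gap go beyond it, so compound 2 cannot be set apart from compound 3 on the present data.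

Compound 4 `Oc1c(Cc2ccc(Cl)cc2)ccc2ccccc12` has not yet been run in this assay. It differs from compound 2 by chloro in place of methoxy on an aromatic carbon. No measured step concerns a change of this kind; the one step on record replaces one pendant ring by another and is modest in size, so the series has so far shown only moderate movement for changes on the pendant ring. For the measured compounds named here, with no direct precedent, the expectation for compound 4 is a step within the scatter, in either direction, giving an expected 1.3-fold higher number from compound 2 to compound 4 (0.12 log units; within the scatter). Compound 4 is therefore estimated at 100 nM, with a range from 40 nM to 250 nM.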

Compound 4, half-maximal inhibitory concentration: 39 nM
Beside the measured number, compound 4's estimate is 2.6-fold (0.41 log units) above it, outside the stated range (below it).
By their numbers in this assay, from the lowest: compounds 4, 2 and 3 (each within the scatter of the next, the first and the last beyond it); then compound 1.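

In this assay, among the compounds shown here, this is the first measured change of a substituent on the carbon-only pendant ring rather than of the ring itself: with chloro in place of methoxy, para to a large group, the series shows a 1.9-fold lower number from compound 2 to compound 4 (0.28 log units; within the scatter). This position therefore accepts a swap from two heavy atoms and one hydrogen-bond acceptor to one heavy atom and no hydrogen-bond acceptor without the number leaving the scatter, so for this pair the acceptor counted on methoxy is not needed to hold the number in this range. No measurement in hand bears on why the two groups read alike, and the pair does not set chloro apart from methoxy.

The compounds shown leave open what a plain hydrogen at this position gives, so neither chloro nor methoxy can yet be compared with an unsubstituted ring. Also open, on these data alone, is whether the position would accept an amine, a carboxylic acid or a longer chain such as butoxy as readily as it accepts these two groups.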